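Dropping a Chloro Group Across Two Cores

A few compounds are considered here, and "the series" means these few. Any claim that something is new, unique, unknown or untested is made for them only; others in the source may bear on it.

Of the compounds shown here, three have been tested in a functional assay on MCF7 cells (Homo sapiens) for cytotoxicity, read by MTT assay, with a stated time of 72 h; on this read-out higher numbers stand for weaker inhibition and lower numbers for stronger inhibition. Compound 1 `O=c1cc(CSc2nc3ccccc3s2)oc2ccccc12` shows > 25000 nM, which is a limit of the assay rather than a number. Compound 3 `O=c1cc(CSc2nc3ccccc3s2)oc2ccc(Cl)cc12` gives > 25000 nM, also a limit. Compound 2 `Cc1cc(C)nc(SCc2cc(=O)c3cc(Cl)ccc3o2)n1` gives > 25000 nM, again a limit. Compound 1 and compound 3 differ by hydrogen in place of chloro on an aromatic carbon; the step that the two limits leave unreadable from compound 3 to compound 1 cannot be read, because of the limit of > 25000 nM in this assay, at which 3 of the 3 values shown sit. Compound 2 and compound 3 are built on different cores, and the difference between the two cores is not broken down here. Compound 4 `Cc1cc(C)nc(SCc2cc(=O)c3ccccc3o2)n1`, not yet measured, arises from compound 2 by hydrogen in place of chloro on an aromatic carbon, the same change already seen from compound 3 to compound 1. This change is expected to give a step that the limit leaves unreadable from compound 2 to compound 4, resting on compound 3 and compound 1, where the change left both values sitting at the limit of > 25000 nM in this assay, at which 3 of the 3 values shown sit. Compound 4 is therefore expected to give about 30000 nM, most probably once more as a limit, with a range from 10000 nM to 100000 nM.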

Compound 4, half-maximal inhibitory concentration: > 25000 nM
Compound 4 gave a limit, no number; the forecaster's own chance of this, stated with the estimate: 85%; the middle value is on the limit's open side.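

In this assay compound 4 gives > 25000 nM, a limit and not a number. Compound 2 also sits at a limit, so no step can be read between compound 2 and compound 4: the limit of > 25000 nM in this assay, at which 4 of the 4 values shown sit.

With no actual number among them, the compounds shown leave open whether hydrogen in place of chloro changes the inhibition on either core.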